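From ethyl to methyl in a narrow series

A few compounds are considered here, and "the series" means these few. Any claim that something is new, unique, unknown or untested is made for them only; others in the source may bear on it.

Of the compounds shown here, three that share one core have been read in a functional assay on HeLa cells (Homo sapiens) for inhibition, read by CCK-8 assay, with a stated time of 72 h, tested at 2 uM; a higher number here means more inhibition of growth at the concentration tested, a lower number less inhibition of growth. Compound 1 (`Nc1ccccc1NC(=O)/C=C/c1ccc(CSc2ccc(Cl)cc2)cc1`) gives 1.94%, compound 2 (`Nc1ccccc1NC(=O)/C=C/c1ccc(CSc2cccc(F)c2)cc1`) gives 2.25%, and compound 3 (`CCc1ccc(SCc2ccc(/C=C/C(=O)Nc3ccccc3N)cc2)cc1`) gives 3.96%. Compound 3 therefore stands level with the other two, its gaps to both lying within the scatter.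

The next compound is compound 4 (`Cc1ccc(SCc2ccc(/C=C/C(=O)Nc3ccccc3N)cc2)cc1`). It differs from compound 3 as follows: hydrogen in place of methyl on a saturated chain carbon bound to an aromatic carbon. This is hydrogen in place of methyl on a saturated chain carbon bound to an aromatic carbon, which turns ethyl to methyl and 4-ethylphenyl to 4-methylphenyl.

Among the compounds with values here, no measured step makes this exact change, so the evidence is indirect. The nearest steps alter the same group on the sulfur. Ethyl in place of chloro gave a number 2 percentage points higher from compound 1 to compound 3 (within the scatter), and 4-ethylphenyl in place of 3-fluorophenyl gave a number 1.7 percentage points higher from compound 2 to compound 3 (within the scatter). 3-Fluorophenyl in place of 4-chlorophenyl gave a number 0.3 percentage points higher from compound 1 to compound 2 (within the scatter). None of these exchanges left the scatter, so no step beyond the scatter is expected in this assay for the loss of one carbon.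

The expected step is a number 1 percentage points lower from compound 3 to compound 4 (within the scatter). For compound 4 the estimated value is 3%, with an expected range of 0% to 10%.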

Compound 4, percent growth inhibition at one concentration: 25.5%
Estimate against measurement, compound 4: 22.5 percentage points below, and the stated range ends below it.
By their numbers in this assay, from the lowest: compounds 1, 2 and 3 (each within the scatter of the next); then compound 4.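

In this assay, the exchanges on the sulfur among compounds 1, 2 and 3 had all stayed within the scatter, but the change from ethyl to methyl gives a number 21.5 percentage points higher from compound 3 to compound 4 (beyond the scatter), showing that this single saturated chain carbon bound to an aromatic carbon is not indifferent to the read-out. The other two steps place compound 4 apart in the same way: methyl in place of chloro on an aromatic carbon gives a number 23.6 percentage points higher from compound 1 to compound 4 (beyond the scatter), and 4-methylphenyl in place of 3-fluorophenyl gives a number 23.3 percentage points higher from compound 2 to compound 4 (beyond the scatter), so among these four compounds only the one carrying 4-methylphenyl stands clear of the rest. Nothing available accounts for this separation, and the result remains an observation without an explanation.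

The compounds shown leave open whether methyl itself is what matters, since an unsubstituted phenyl or a 4-methoxyphenyl on the sulfur would test how narrow the effect is. They also leave open how far the separation of compound 4 holds at other concentrations, as all four compounds are read here at a single concentration in one cell line.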